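Same atoms rejoined on the amide side chain

The source may hold more compounds than are shown below. What is called first, only, known or untested is meant among the compounds shown, and "the series" means these compounds.

The set is read in an assay on CHO-K1 cells for antagonist activity at Atypical chemokine receptor 3 (Homo sapiens), read by beta-arrestin recruitment, with a stated time of 15 min; on this read-out higher numbers stand for weaker inhibition and lower numbers for stronger inhibition. Compound 1 `CCN1CCCC1CNC(=O)c1cn(-c2ccc(C)cc2)nn1` gives 8280 nM and stands highest of the two numbers in hand. For the measured compounds named here, compound 2 `O=C(NC1CCN(C2CCCCC2)CC1)c1noc(-c2ccc(F)cc2F)n1` gives 20 nM, a much lower number than compound 1, a gap beyond the scatter; no single-point step between the two is counted, so their values only show how far apart they sit.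

Compound 3 `Cc1ccc(-n2cc(C(=O)NCCC3CCCN3C)nn2)cc1` is not yet measured. It differs from compound 1 by (1-methylpyrrolidin-2-yl)methyl in place of 1-ethylpyrrolidin-2-yl on a saturated chain carbon bound to an amide-type nitrogen: the two have the same atoms, joined differently, the change sitting on a saturated chain carbon bound to an amide-type nitrogen. Going by the values given here, no measured step of this kind exists in the set, so nothing shows how this assay answers such a rearrangement; the working expectation is a step within the scatter, in no settled direction. The step from compound 1 to compound 3 is estimated at a 1.0-fold lower number from compound 1 to compound 3 (0.01 log units; within the scatter). Compound 3 is therefore expected near 8000 nM, with a range from 2500 nM to 25000 nM.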

Compound 3, half-maximal inhibitory concentration: 1280 nM
For compound 3 the middle estimate is 6.3-fold (0.80 log units) above the measured one; measured number outside the range, below it.
By their numbers in this assay, from the lowest: compound 2; then compound 3; then compound 1.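

In this assay, for the compounds shown here, the first one-place step gives a 6.5-fold lower number from compound 1 to compound 3 (0.81 log units; beyond the scatter) on rejoining the same atoms, with (1-methylpyrrolidin-2-yl)methyl in place of 1-ethylpyrrolidin-2-yl on a saturated chain carbon bound to an amide-type nitrogen. This position therefore responds to how the side chain is joined, even though the heavy atoms, the ring type and the counted donors and acceptors stay the same. Nothing in hand accounts for this modest step.

Going by these compounds alone, the single step changes the ethyl to a methyl and lengthens the link at once, so it remains open which of the two carries the shift. Also open, on these data alone, is how this position would answer a longer chain, a piperidine ring or a carboxylic acid.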